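Swapping a Halogenated Phenyl Ring in a Cytotoxicity Series

The compounds below may be only part of what the source reports. "The series", "measured", "known", "first", "only" and "open" are said of these compounds alone.

Of the compounds shown here, two have been measured so far. Compound 1 `CNC(=O)c1cc(Oc2ccc(NC(=O)c3nn(-c4cccc(F)c4)c(=O)cc3C)cc2F)ccn1` and compound 2 `Cc1cc(=O)n(-c2ccc(Br)cc2F)nc1C(=O)Nc1ccc(Oc2ncnc3ccsc23)c(F)c1` share a core but differ at both ends. In a functional assay on A549 cells (Homo sapiens) for cytotoxicity, read by MTT assay, with a stated time of 72 h (a higher number here means a weaker inhibitor, a lower number a stronger inhibitor), compound 1 gives 9540 nM, while compound 2 gives 2980 nM, the lower of the two numbers and a gap to compound 1 that lies beyond the scatter. Compound 3 `Cc1cc(=O)n(-c2cccc(F)c2)nc1C(=O)Nc1ccc(Oc2ncnc3ccsc23)c(F)c1` differs from compound 2 in one place: 3-fluorophenyl in place of 4-bromo-2-fluorophenyl on an aromatic nitrogen. Among the measured compounds shown here, no pair of measured compounds isolates this change, and compound 1, which also carries the 3-fluorophenyl, differs from compound 2 elsewhere as well, so its number cannot be read as the effect of that ring alone. The expected step for this change is small and toward a higher number, close to the edge of the scatter, as a 1.7-fold higher number from compound 2 to compound 3 (0.22 log units; within the scatter). Compound 3 is therefore estimated to give about 5000 nM, within a range from 2000 nM to 15000 nM.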

Compound 3, half-maximal inhibitory concentration: 5220 nM
The estimate for compound 3 lay 1.0-fold (0.02 log units) below the measured number; measured number inside the range.
By their numbers in this assay, from the lowest: compounds 2, 3 and 1 (each within the scatter of the next, the first and the last beyond it).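

In this assay, among the compounds shown here, the first single change at this position, 3-fluorophenyl in place of 4-bromo-2-fluorophenyl on the aromatic nitrogen, gives a 1.8-fold higher number from compound 2 to compound 3 (0.24 log units; within the scatter), so losing the bromine and changing the fluorine's place has no effect that can be told apart from scatter. With the 3-fluorophenyl now held fixed, the group on the oxygen on an aromatic ring can also be read alone, and that swap gives a 1.8-fold lower number from compound 1 to compound 3 (0.26 log units; within the scatter), so neither single change moves the number beyond the scatter. Nothing available here accounts for the size of these steps.

Still open, going by these compounds, is whether the bromine and the fluorine's place each matter separately, since this step changes both at once. On these data alone, it is also open how a quite different group on that nitrogen, such as a carboxylic acid or a longer alkyl chain, would read.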